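The source may hold more compounds than are shown below. What is called first, only, known or untested is meant among the compounds shown, and "the series" means these compounds.

Compound 3 `O=C(CN1CCN(c2ccccc2F)CC1)Nc1nc2ccccc2[nH]1` gives 56.6% in a functional assay, read by spectrophotometry, with a stated time of 30 min, tested at 150 ug/mL; a higher number here means a stronger effect of the compound at the concentration tested, a lower number a weaker effect. Among the three measured compounds it stands within the scatter of both others: compound 2 `CCN1CCN(CC(=O)Nc2nc3ccccc3[nH]2)CC1` gives 57.5% in this assay, and compound 1 `CN1CCN(CC(=O)Nc2nc3ccccc3[nH]2)CC1` gives 54.3%. Compound 4 `O=C(CN1CCN(c2ncccn2)CC1)Nc1nc2ccccc2[nH]1` differs from compound 3 by pyrimidin-2-yl in place of 2-fluorophenyl on an amine nitrogen in a ring. Among the compounds with values here, the steps that bear on this change are the two earlier exchanges at the same ring nitrogen, a number 2.3 percentage points higher from compound 1 to compound 3 (within the scatter) and a number 0.9 percentage points lower from compound 2 to compound 3 (within the scatter). Because a number 2.3 percentage points higher from compound 1 to compound 3 (within the scatter) and a number 0.9 percentage points lower from compound 2 to compound 3 (within the scatter) both lie within the scatter, the step expected here is a number 0.6 percentage points lower from compound 3 to compound 4 (within the scatter), that is, none beyond the scatter. Compound 4 is therefore estimated to give 56% in this assay, with a range from 46% to 66%.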

Compound 4, a percentage reported as activity, at one concentration (the size of the read-out at that concentration, not a potency): 68.4%
Compound 4: the middle estimate sits 12.4 percentage points below what was measured; measured number above the stated range.
By their numbers in this assay, from the lowest: compounds 1, 3 and 2 (each within the scatter of the next); then compound 4.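

At the amine nitrogen in a ring, methyl, ethyl and 2-fluorophenyl stood within the scatter of one another in this assay, whereas pyrimidin-2-yl separates from all three, with a number 11.8 percentage points higher from compound 3 to compound 4 (beyond the scatter) and a number 10.9 percentage points higher from compound 2 to compound 4 (beyond the scatter) and a number 14.1 percentage points higher from compound 1 to compound 4 (beyond the scatter) as modest steps. The entering ring carries 2 hydrogen-bond acceptors where the leaving 2-fluorophenyl carries 0, but nothing available explains the higher number. Still open, from the compounds shown here alone, is whether both ring nitrogens of pyrimidin-2-yl are needed, which a pyridin-2-yl or unsubstituted phenyl group at this nitrogen could address.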